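The source may hold more compounds than are shown below. What is called first, only, known or untested is meant among the compounds shown, and "the series" means these compounds.

Measured in an ADME assay on DU-145 cells (Homo sapiens) for cytotoxicity, read by MTT assay, with a stated time of 72 h; a lower number here means a stronger inhibitor, a higher number a weaker inhibitor:
- Compound 1 `COc1ccc(C2=C(c3cc(OC)c(OC)c(OC)c3)C(=O)C(OC(C)=O)C2)cc1OC(C)C`: > 100 ug/mL (a limit)
- Compound 2 `COc1ccc(C2=C(c3cc(OC)c(OC)c(OC)c3)C(=O)C(O)C2)cc1NC(=O)c1ccccc1`: > 100 ug/mL (a limit)
- Compound 3 `COc1ccc(C2=C(c3cc(OC)c(OC)c(OC)c3)C(=O)C(O)C2)cc1Cl`: 40 ug/mL

Going by the values given here, compound 3 holds the only true number. Compounds 1 and 2 stand at the limit of > 100 ug/mL in this assay, at which 2 of the 3 values shown sit. Compound 4 `COc1ccc(C2=C(c3cc(OC)c(OC)c(OC)c3)C(=O)C(O)C2)cc1OC(C)C` puts isopropoxy in place of chloro on an aromatic carbon, ortho to a methoxy group: isopropoxy in place of chloro on an aromatic carbon. Among the compounds with values here, the one measured step on this carbon is an at least 2.5-fold lower number from compound 2 to compound 3 (0.39 log units; beyond the scatter), with chloro in place of benzamido. Compound 1, which also carries isopropoxy but differs elsewhere on the core, gives > 100 ug/mL, again a limit. A modest loss is therefore expected in this assay, an estimated 2.3-fold higher number from compound 3 to compound 4 (0.35 log units; beyond the scatter), towards a higher number. Compound 4 is estimated at 90 ug/mL, with an expected range of 35 ug/mL to 200 ug/mL.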

Compound 4, half-maximal inhibitory concentration: > 100 ug/mL
Compound 4: no number, only a limit (the forecaster's own chance of this, stated with the estimate: 50%); middle value at least 1.1-fold (0.04 log units) away from the limit.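

Chloro remains the only group on this aromatic carbon with a true number; compound 4 gives only a limit, yet isopropoxy in place of chloro, with the rest of the structure unchanged, still reads as an at least 2.5-fold higher number from compound 3 to compound 4 (0.39 log units; beyond the scatter) in this assay. The steps to compound 4 from compound 2 and from compound 1 cannot be read, as both ends are limits. Isopropoxy and benzamido on this carbon now both end at that limit: the limit of > 100 ug/mL in this assay, at which 3 of the 4 values shown sit.

Open, on these data alone, is how a fluoro, a methyl or an amine on this carbon would read. As far as these compounds go, the effect of the acetyl on the oxygen also stays open, with compound 1 and compound 4 both at limits.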